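From pyrimidin-5-yl to pyridin-3-yl

A few compounds are considered here, and "the series" means these few. Any claim that something is new, unique, unknown or untested is made for them only; others in the source may bear on it.

compound 1 `CCN(c1ccc(C#N)c(Cl)c1)c1cc(-c2c[nH]nc2C)ccc1C` gives (3190 nM)
compound 2 `N#Cc1ccc(N2CCc3cc(-c4cncnc4)ccc3C2)cc1C(F)(F)F` gives ("not determined" (no result reported))
compound 3 `CCN(c1ccc(C#N)c(C(F)(F)F)c1)c1cc(-n2ccnc2)ccc1C` gives (>= 3920 nM), a limit

Compound 2 has no single number in a functional assay on VCaP cells (Homo sapiens) for antiproliferative activity, read by CCK-8 assay, with a stated time of 6 days; on this read-out higher numbers stand for weaker inhibition and lower numbers for stronger inhibition (its entry reads "not determined" (no result reported)) and so cannot anchor the comparison directly. Compound 3 gives only a limit (>= 3920 nM), and it alone accounts for (the limit of >= 3920 nM in this assay, at which 1 of the 3 values shown sits). Going by the values given here, the one true number in this assay comes from compound 1 (3190 nM), whose core differs from that of compound 2.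

Compound 4 `N#Cc1ccc(N2CCc3cc(-c4cccnc4)ccc3C2)cc1C(F)(F)F` carries pyridin-3-yl in place of pyrimidin-5-yl on an aromatic carbon. The rest of the structure of compound 2 is kept. Among the compounds with values here, no measured pair shows what this exchange does, and compound 2 offers no starting value. No step beyond the usual scatter is therefore expected in this assay, in either direction, and the range must stay wide. Within the data shown here, the expectation leans on compound 1 (3190 nM) as the only available number. For compound 4 the estimated value is 3000 nM, with an expected range from 800 nM to 10000 nM.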

Compound 4, half-maximal inhibitory concentration: 2530 nM
Beside the measured number, compound 4's estimate is 1.2-fold (0.07 log units) above it; the measured number falls inside the stated range.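

In this assay, going by these compounds alone, compound 4 gives 2530 nM but compound 2 has no single number, so no step between them can be read. Going by these compounds, what swapping pyrimidin-5-yl for pyridin-3-yl does to activity stays open. Nothing shown here accounts for the value of compound 4.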